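Swapping an Ortho Fluoro for Trifluoromethoxy

The compounds below may be only part of what the source reports. "The series", "measured", "known", "first", "only" and "open" are said of these compounds alone.

Measured compounds:
- compound 1, `Oc1cccc(-c2cc(-c3ccccc3F)cc(-c3cccc(O)c3)n2)c1`: 4370 nM
- compound 2, `Oc1cccc(-c2cc(-c3cccc(F)c3)cc(-c3cccc(O)c3)n2)c1`: 21300 nM

Both compounds share one core, carrying a fluorinated phenyl group, and were tested in a functional assay on T47D cells (Homo sapiens) for inhibition; on this read-out lower numbers stand for stronger inhibition and higher numbers for weaker inhibition. Compound 1 gives 4370 nM, the lowest of the two numbers. Its nearest neighbour is compound 2, and the step of a 4.9-fold higher number from compound 1 to compound 2 (0.69 log units; beyond the scatter) is a modest worsening that lies beyond the scatter.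

The unmeasured compound 3, `Oc1cccc(-c2cc(-c3ccccc3OC(F)(F)F)cc(-c3cccc(O)c3)n2)c1`, differs from compound 1 in one place: trifluoromethoxy in place of fluoro on an aromatic carbon. The group sits on an aromatic carbon of a six-membered aromatic ring of carbon only, ortho to a large group.

Going by the values given here, no measured step bears directly on this change. Among the compounds with values here, the only step known, from compound 1 to compound 2, moves the fluoro to another position rather than replacing it, so it shows that this ring region matters but not how a larger group there will behave. The expected step of a 1.1-fold higher number from compound 1 to compound 3 (0.06 log units; within the scatter) is therefore small, with a wide range, and compound 3 is estimated at 5000 nM, between 1500 nM and 20000 nM.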

Compound 3, half-maximal inhibitory concentration: 7950 nM
The estimate for compound 3 lay 1.6-fold (0.20 log units) below the measured number, within the range that was stated.
By their numbers in this assay, from the lowest: compounds 1 and 3 (each within the scatter of the next); then compound 2.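

In this assay there is a 1.8-fold higher number from compound 1 to compound 3 (0.26 log units; within the scatter) when trifluoromethoxy takes the place of fluoro, so a group of 5 heavy atoms and a single fluorine atom cannot be told apart at this aromatic carbon, ortho to a large group. The earlier pair showed only that moving the fluoro makes a difference, whereas this result adds that replacing it here with a much bigger group, one that also brings an oxygen atom, leaves the number within ordinary repeat variation. Nothing given here explains why these two groups read alike, and the result alone cannot show whether it is the number of atoms, the oxygen or the fluorine atoms that matter.

The compounds shown leave open whether this tolerance extends beyond these two fluorinated groups, for example to an amine, a carboxylic acid or a longer chain such as ethoxy at the same carbon. They also leave open how trifluoromethoxy would read on the carbon that holds the fluoro in compound 2, and whether any group at either place could give a clearly lower number than compound 1 does.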